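This account rests on a few compounds, and the source may have more. Where it says the series, first, only, none or still open, it means among the compounds named here.

Measured so far:
compound 1 `Cc1[nH]nc(N)c1-c1cccc(OC(F)(F)F)c1`, > 100000 nM
compound 2 `Cc1[nH]nc(N)c1-c1ccc(OCc2ccccc2)cc1`, > 100000 nM
compound 3 `Cc1nn(C(=O)C2CCCC2)c(N)c1-c1ccc(Cl)c(Cl)c1`, 41000 nM

Of the compounds shown here, three share a core and have been tested in an assay on Sf9 cells for inhibition of mitogen-activated protein kinase kinase kinase 14 (Homo sapiens), read by ADP-Glo, with a stated time of 60 min; a lower number here means a stronger inhibitor, a higher number a weaker inhibitor. Compound 1 `Cc1[nH]nc(N)c1-c1cccc(OC(F)(F)F)c1` gives only a limit, > 100000 nM, and no number. Compound 2 `Cc1[nH]nc(N)c1-c1ccc(OCc2ccccc2)cc1` likewise gives only a limit, > 100000 nM. For the measured compounds named here, compound 3 `Cc1nn(C(=O)C2CCCC2)c(N)c1-c1ccc(Cl)c(Cl)c1` is the one compound with an actual number, 41000 nM in this assay, and so it stands alone: the other two values sit at the limit of > 100000 nM in this assay, at which 2 of the 3 values shown sit, and nothing can be said about how far they lie from it.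

Compound 4 `Cc1nn(C(=O)c2ccncc2)c(N)c1-c1ccc(Cl)c(Cl)c1` has not yet been measured. It differs from compound 3 in one place: pyridin-4-yl in place of cyclopentyl on a carbonyl carbon. Going by the values given here, no measured pair shows the effect of this kind of exchange, so there is no step to draw on. With only the value of compound 3 as an anchor, the expected step from compound 3 to compound 4 in this assay is a 1.2-fold lower number from compound 3 to compound 4 (0.07 log units; within the scatter), which is small and within the usual scatter rather than a change in either direction. Compound 4 is therefore estimated at 35000 nM, with a range from 8000 nM to 150000 nM, and a real chance that this assay again returns only a limit.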

Compound 4, half-maximal inhibitory concentration: 58200 nM
Compound 4: middle estimate off by 1.7-fold (0.22 log units), on the low side; the measured number falls inside the stated range.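

In this assay, for the compounds shown here, putting pyridin-4-yl in place of cyclopentyl on a carbonyl carbon gives a 1.4-fold higher number from compound 3 to compound 4 (0.15 log units; within the scatter) as the first step that can be read at this position. It shows that, on this carbonyl carbon, a six-membered aromatic ring with one hetero atom and one hydrogen-bond acceptor can replace a five-membered non-aromatic ring of carbon only without a shift beyond the scatter, and the number stays measurable rather than falling to a limit. No measurement shown here bears on the cause of this small step.

From the compounds shown here alone, whether an amine, a carboxylic acid or a longer alkyl chain on the same carbonyl carbon would move the number beyond the scatter remains open. A single exchange also leaves open whether changes elsewhere on the shared core would do so.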